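The source may hold more compounds than are shown below. What is called first, only, known or untested is meant among the compounds shown, and "the series" means these compounds.

Three compounds share one core in a functional assay on L1210 cells (Mus musculus) for cytotoxicity, read by cell counting, with a stated time of 2 days; on this read-out lower numbers stand for stronger inhibition and higher numbers for weaker inhibition. Compound 1 `Nc1ccc(/C=C2\SC(=O)N(Cc3ccc(Cl)cc3)C2=O)cc1` gives 37000 nM, compound 2 `C=C(Br)C(=O)Nc1ccc(/C=C2\SC(=O)N(Cc3cccc(Cl)c3)C2=O)cc1` gives 3400 nM, and compound 3 `Nc1ccc(/C=C2\SC(=O)N(Cc3ccccc3)C2=O)cc1` gives 38000 nM. Within the data shown here, compound 3 has the highest of the three numbers, yet its value and that of compound 1 lie within the scatter of one another; the one measured step between them, a 1.0-fold higher number from compound 1 to compound 3 (0.01 log units; within the scatter), amounts to nothing beyond the scatter. Compound 2 stands furthest from compound 3, but it differs in more than one place, so its lower number is not read as a single step.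

Compound 4 `Nc1ccc(/C=C2\SC(=O)N(Cc3cccc(Cl)c3)C2=O)cc1` is reached from compound 3 by one change: chloro in place of hydrogen on an aromatic carbon. Among the measured compounds shown here, the one step that bears on this change, a 1.0-fold higher number from compound 1 to compound 3 (0.01 log units; within the scatter), is the introduction of hydrogen in place of chloro at another position of the same ring, and it left the number essentially unchanged. For the measured compounds named here, the data hold no step at the position now in question, so the expectation rests on that single step alone. Compound 4 is therefore expected to show a step of no change at the digits printed from compound 3 to compound 4 (within the scatter) in this assay, that is, none beyond the scatter. Compound 4 is estimated at 38000 nM, with a range from 19000 nM to 76000 nM.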

Compound 4, half-maximal inhibitory concentration: 4700 nM
Compound 4: middle estimate off by 8.1-fold (0.91 log units), on the high side, and the stated range ends above it.
By their numbers in this assay, from the lowest: compounds 2 and 4 (each within the scatter of the next); then compounds 1 and 3 (each within the scatter of the next).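

In this assay, chloro in place of hydrogen at this carbon, meta to a large group, proves to be a real change: an 8.1-fold lower number from compound 3 to compound 4 (0.91 log units; beyond the scatter) stands beyond the scatter, whereas the earlier step on the same ring, a 1.0-fold higher number from compound 1 to compound 3 (0.01 log units; within the scatter), did not. The comparison between the two chloro compounds points the same way, since 3-chlorophenyl in place of 4-chlorophenyl gives a 7.9-fold lower number from compound 1 to compound 4 (0.90 log units; beyond the scatter), so among these compounds the position of the chlorine matters and not merely its presence. The result also recasts the acylated compound: hydrogen in place of (1-bromoethenyl)carbonyl on the nitrogen gives a 1.4-fold higher number from compound 2 to compound 4 (0.14 log units; within the scatter), within the scatter, so with 3-chlorophenyl in place that group brings no difference that can be told from the scatter.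

The compounds shown leave open whether a fluoro, a methyl or a methoxy group at this carbon would give a number like that of compound 4, and whether the (1-bromoethenyl)carbonyl group would matter on the phenyl or 4-chlorophenyl compounds. Nothing given here accounts for the difference between the two chlorine positions.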